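The source may hold more compounds than are shown below. What is called first, only, known or untested is meant among the compounds shown, and "the series" means these compounds.

Measured so far in a functional assay on HeLa cells (Homo sapiens) for cytotoxicity, read by MTT assay, with a stated time of 2 days, tested at 1 uM; on this read-out higher numbers stand for a weaker effect at the one concentration tested and lower numbers for a stronger effect:
compound 1 `CC(=O)c1cc(-c2ccccc2)cc2cc(-c3ccccc3)[nH]c12`: 65.8%
compound 2 `COc1ccc(-c2cc(C(C)=O)c3[nH]c(-c4ccccc4)cc3c2)cc1`: 73.1%

Within the data shown here, compound 2 holds the highest of the two numbers in this assay, with compound 1 as its nearest neighbour; the only measured step, a number 7.3 percentage points higher from compound 1 to compound 2 (within the scatter), lies within the scatter, so the two compounds are not separated on this read-out.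

Compound 3 `CC(=O)c1cc(/C=C/c2ccc(F)cc2)cc2cc(-c3ccccc3)[nH]c12` differs from compound 2 by 2-(4-fluorophenyl)ethenyl in place of 4-methoxyphenyl on an aromatic carbon. Among the measured compounds shown here, no measured step concerns an exchange of this kind: the single step, a number 7.3 percentage points higher from compound 1 to compound 2 (within the scatter), covers a change on the 4-methoxyphenyl that is itself removed here, and it was within the scatter. Nothing therefore points to a step beyond the scatter in either direction in this assay, and the expectation rests only on the spread of the two measured compounds. Compound 3 is expected to give 69%, with a range from 45% to 92%. The expected step of a number 4.1 percentage points lower from compound 2 to compound 3 (within the scatter) is small.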

Compound 3, a percentage reported as activity, at one concentration (the size of the read-out at that concentration, not a potency): 70%
Beside the measured number, compound 3's estimate is 1 percentage points below it; measured number inside the range.
By their numbers in this assay, from the lowest: compounds 1, 3 and 2 (each within the scatter of the next).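

In this assay, the position on the shared core that is para to a fused ring and meta to an acetyl group accepts 2-(4-fluorophenyl)ethenyl in place of 4-methoxyphenyl, with a number 3.1 percentage points lower from compound 2 to compound 3 (within the scatter) as the step, and in place of phenyl, with a number 4.2 percentage points higher from compound 1 to compound 3 (within the scatter) as the step. The earlier pair showed only a methoxy exchange on an aromatic ring already at this position, whereas this change also adds a double bond outside aromatic rings and a fluorine, and compound 3 still is not separated from either neighbour. No measurement at hand bears on why these exchanges leave the read-out unseparated.

All three compounds carry a six-membered aromatic ring of carbon only in the group at this position, so a step beyond the scatter remains undefined here. An amine, a carboxylic acid or a longer alkyl chain at this position could test whether any exchange there separates compounds on this read-out.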